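The source may hold more compounds than are shown below. What is called first, only, known or untested is meant among the compounds shown, and "the series" means these compounds.

Working notes on the series, read in an ADME assay on MRC5 cells (Homo sapiens) for cytotoxicity, read by fluorescence, with a stated time of 72 h; on this read-out higher numbers stand for weaker inhibition and lower numbers for stronger inhibition. Compound 1 `CC1(COc2ccc(Cl)cc2)Cn2cc([N+](=O)[O-])nc2O1` gives > 64000 nM, which is a limit of the assay. Compound 2 `O=[N+]([O-])c1cn2c(n1)OC(COc1ccc(-c3ccc(F)cc3)nc1)C2` gives > 64000 nM, likewise a limit of the assay. Compound 2 thus stands at the limit of > 64000 nM in this assay, at which 2 of the 2 values shown sit, and no actual number is known for it. Compound 3 `O=[N+]([O-])c1cn2c(n1)O[C@H](COc1ccc(-c3ccc(F)cc3)nc1)C2` differs from compound 2 in one element only: the two compounds have the same atoms and bonds; at least one stereo element is drawn with a configuration in one of them and without one in the other: 1 of 1 stereo elements differ; a stereocentre at a saturated ring carbon is drawn without a configuration in compound 2 and S in compound 3. The atoms and bonds stay the same, and only the stereocentre at a saturated ring carbon, drawn without a configuration in compound 2, is drawn S in compound 3. No change beyond the scatter is expected in this assay, and the estimated a number no higher from compound 2 to compound 3 (the limit leaves the size open) reflects that. This expectation rests on compound 2, which gives the limit > 64000 nM. Compound 3 is expected at 64000 nM, with an estimated range from 32000 nM to 100000 nM, and the assay will probably report a limit again.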

Compound 3, half-maximal inhibitory concentration in the MRC5 assay: > 64000 nM
Compound 3 was reported as a limit; the forecaster's own chance of this, stated with the estimate: 85%; the middle value sits exactly at the limit.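

In the MRC5 assay compound 2 gives > 64000 nM, which is a limit of the assay. In the MRC5 assay compound 3 gives > 64000 nM, likewise a limit of the assay. No step can be read from compound 2 to compound 3, because both compounds sit at the same limit of the assay: the limit of > 64000 nM in the MRC5 assay, at which 3 of the 3 values shown sit.

In a physicochemical assay for solubility, read by HPLC, measured as kinetic solubility, at 20 degrees C, at pH 7 (on this read-out higher numbers stand for higher solubility and lower numbers for lower solubility), compound 2 gives 1.3 ug/mL and compound 3 gives 1.4 ug/mL. In the physicochemical assay this is a 1.1-fold higher number from compound 2 to compound 3 (0.03 log units; within the scatter).

The compounds shown leave open what actual numbers compound 2 and compound 3 would give in the MRC5 assay, and whether the S stereocentre of compound 3 makes any difference to this read-out.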